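The compounds below may be only part of what the source reports. "The series", "measured", "known", "first", "only" and "open" are said of these compounds alone.

Measured compounds:
compound 1 `C=COc1cncc(N2CCNCC2)c1` — 18%
compound 2 `COc1ccc(N2CCCNCC2)cn1` — 88%
compound 3 `Clc1cncc(N2CCNCC2)c1` — 41%

In an assay on HEK293 cells with Neuronal acetylcholine receptor; alpha4/beta2 (Homo sapiens) as the target, read by FLIPR and calcium flux (a higher number here means a larger maximal response, a lower number a smaller maximal response), compound 3 stands second highest of the three numbers. Its nearest neighbour is compound 1, which in this assay gives 18%, and the difference between them is beyond the scatter; the furthest is compound 2, which in this assay gives 88%, also beyond the scatter. Going by the values given here, the one step measured within the set, a number 23 percentage points higher from compound 1 to compound 3 (beyond the scatter), is a modest one and concerns an exchange of one group for another at the same carbon.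

The piece now turns to compound 4 `Cc1ncc(N2CCNCC2)cc1Cl`, which differs from compound 3 in one place: methyl in place of hydrogen on an aromatic carbon. Among the compounds with values here, no measured step concerns a methyl entering in place of hydrogen, and compound 2 differs from compound 3 in more than one place, so its value cannot be read as a step. With nothing bearing directly on this change, no step beyond the scatter is expected in this assay. Compound 4 is therefore estimated at 45%, with a range from 20% to 75%. Within the data shown here, the expected step of a number 4 percentage points higher from compound 3 to compound 4 (within the scatter) reflects only this absence of guidance.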

Compound 4, largest response reached (reported as efficacy), in percent of the reference or control that the assay uses: 74%
Compound 4: the middle estimate sits 29 percentage points below what was measured; the range from low to high includes it.
By their numbers in this assay, from the lowest: compound 1; then compound 3; then compound 4; then compound 2.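

Going by these compounds alone, until this result, the only step measured within the set concerned the carbon carrying the chloro group. Compound 4 shows that a second place matters in this assay: a methyl on the aromatic carbon next to the ring nitrogen and ortho to a chloro group gives a number 33 percentage points higher from compound 3 to compound 4 (beyond the scatter), a large step from one added heavy atom, with the chloro group kept in both compounds. Nothing among the data given accounts for this step.

The compounds shown do not tell whether an ethyl chain, a methoxy group or a fluorine at this carbon would give a similar step. They also leave open whether methyl would have the same effect on the maximal response in a compound without the chloro group.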